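Trading nitro for fluoro on a weakly cytotoxic compound

A few compounds are considered here, and "the series" means these few. Any claim that something is new, unique, unknown or untested is made for them only; others in the source may bear on it.

In a functional assay on A549 cells (Homo sapiens) for cytotoxicity, read by MTT assay, with a stated time of 4 days (on this read-out higher numbers stand for weaker inhibition and lower numbers for stronger inhibition), compound 1 (`COc1cc(C[C@H]2C(=O)OC[C@@H]2Cc2ccc(OC)c(OC)c2)ccc1NC(=O)c1ccccc1`) gives > 50000 nM, which is a limit of the assay and not a true number. Among the compounds with values here, compound 2 (`COc1cc(C[C@H]2C(=O)OC[C@@H]2Cc2ccc(OC)c(OC)c2)ccc1Nc1ccc([N+](=O)[O-])cc1`) gives 22100 nM, the only true number so far. Within the data shown here, the one measured step is an at least 2.2-fold lower number from compound 1 to compound 2 (0.35 log units; beyond the scatter). On these data alone, that step starts from compound 1 at the limit of > 50000 nM in this assay, at which 1 of the 2 values shown sits, so its full size stays open. Compound 3 (`COc1cc(C[C@H]2C(=O)OC[C@@H]2Cc2ccc(OC)c(OC)c2)ccc1Nc1ccc(F)cc1`) turns 4-nitrophenyl into 4-fluorophenyl, with fluoro in place of nitro on an aromatic carbon. The measured step replaced the whole benzoyl group, so it gives no direct size for this smaller change, and the expectation rests on compound 2 at 22100 nM. The expected step is a 1.4-fold higher number from compound 2 to compound 3 (0.13 log units; within the scatter), slightly upward and not expected to pass beyond the scatter. In this assay the estimate for compound 3 is 30000 nM, expected between 12000 nM and 50000 nM.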

Compound 3, half-maximal inhibitory concentration: > 50000 nM
Compound 3: only a limit was reported (the forecaster's own chance of this, stated with the estimate: 30%); at least 1.6-fold (0.22 log units) between middle value and limit.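

In this assay, fluoro in place of nitro on an aromatic carbon, para to a large group, gives an at least 2.2-fold higher number from compound 2 to compound 3 (0.35 log units; beyond the scatter), so the small measurable activity of compound 2 depends on the group at this position. The earlier step from compound 1 to compound 2 changed the benzoyl group as a whole, and it could not show whether any aryl group on that nitrogen would be enough; compound 3 keeps a phenyl ring there and still reaches only a limit of the assay. Compound 1 also stands at a limit, so the step between compound 1 and compound 3 cannot be read: the limit of > 50000 nM in this assay, at which 2 of the 3 values shown sit.

On these data alone, the full size of the loss on leaving nitro stays open. As far as these compounds go, it is also open whether an amine, a nitrile or a carboxylic acid at this position would match compound 2 or go beyond it.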